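Adding a Methyl to the Amide Nitrogen of Compound 2

The source may hold more compounds than are shown below. What is called first, only, known or untested is meant among the compounds shown, and "the series" means these compounds.

Compound 2 `CCNC(=O)/C=C1\CCc2ccc(F)cc21` gives 63% in a functional assay on the whole organism with Rattus norvegicus as the target, at a dose of 20 mg/kg by the oral route (on this read-out lower numbers stand for less inhibition and higher numbers for more inhibition at the one dose given (going by the name of the read-out)), the highest of the three numbers measured. Going by the values given here, compound 3 `NC(=O)/C=C1\CCc2cc(F)ccc21` gives 42%, and compound 1 `NC(=O)/C=C1\CCc2cc(Cl)ccc21` gives 29%; the only step between two compounds that differ in one place is a number 13 percentage points higher from compound 1 to compound 3 (beyond the scatter). Compound 4 `CCN(C)C(=O)/C=C1\CCc2ccc(F)cc21` differs from compound 2 by methyl in place of hydrogen on an amide-type nitrogen, so the ethylamino group becomes ethyl(methyl)amino. Among the compounds with values here, no measured step touches the amide nitrogen, and the fluoro-for-chloro step on the aromatic carbon says nothing about such a change, so the direction of any shift in this assay is open. The expected step is therefore small and uncertain, a number 8 percentage points lower from compound 2 to compound 4 (within the scatter). Compound 4 is expected to give about 55%, within a range from 30% to 75%.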

Compound 4, a percentage reported as inhibition, in the whole organism at one dose (the size of the read-out at that dose, not a potency): 44%
Compound 4: the middle estimate sits 11 percentage points above what was measured, within the range that was stated.
By their numbers in this assay, from the lowest: compound 1; then compounds 3 and 4 (each within the scatter of the next); then compound 2.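

In this assay, the change from ethylamino to ethyl(methyl)amino gives a number 19 percentage points lower from compound 2 to compound 4 (beyond the scatter). Going by these compounds alone, this is the first measured step at the amide nitrogen, and it shows that the read-out responds to a single added methyl at this position, with the amide hydrogen present in the higher-reading compound. No measurement here explains the drop.

The compounds shown leave open whether a longer chain such as propyl in place of that methyl would lower the number further. They also leave open whether the same methyl change would give a similar step on other compounds in the series.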